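Swapping the amide ring of an oxazole ketone FAAH inhibitor

The source may report more compounds than this note shows. Statements on the series, on what has been measured and on what is new or still open speak of the compounds shown alone.

Measured compounds:
compound 1, `O=C(CCCCCCc1ccccc1)c1ncc(-c2cccc(O)c2)o1`, 50 nM in an assay (Rattus norvegicus) for inhibition of Fatty-acid amide hydrolase 1 (Homo sapiens); a lower number here means a stronger inhibitor, a higher number a weaker inhibitor
compound 2, `O=C(CCCCCCc1ccccc1)c1ncc(-c2ccc(F)cc2)o1`, 62 nM
compound 3, `CN1CCN(C(=O)c2cnc(C(=O)CCCCCCc3ccccc3)o2)CC1`, 80 nM

The three numbers sit within the usual scatter of one another: a 1.2-fold higher number from compound 1 to compound 2 (0.09 log units; within the scatter), a 1.6-fold higher number from compound 1 to compound 3 (0.20 log units; within the scatter) and a 1.3-fold higher number from compound 2 to compound 3 (0.11 log units; within the scatter). Compound 3 therefore cannot be set apart from the other two. Compound 4, `O=C(CCCCCCc1ccccc1)c1ncc(C(=O)N2CCSCC2)o1`, differs from compound 3 by thiomorpholin-4-yl in place of 4-methylpiperazin-1-yl on a carbonyl carbon. Within the data shown here, none of the measured steps touches this carbonyl-bound ring; each of them only exchanges the group on the aromatic carbon, and those exchanges stayed within the scatter. There is thus no basis for expecting a shift beyond the scatter in this assay, in either direction. Compound 4 is expected to give about 90 nM, between 35 nM and 230 nM. The expected step is a 1.1-fold higher number from compound 3 to compound 4 (0.05 log units; within the scatter).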

Compound 4, inhibition constant: 10 nM
Compound 4: middle estimate off by 9.0-fold (0.95 log units), on the high side; measured number below the stated range.
By their numbers in this assay, from the lowest: compound 4; then compounds 1, 2 and 3 (each within the scatter of the next).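

In this assay, among these compounds, the ring on the carbonyl carbon matters: thiomorpholin-4-yl in place of 4-methylpiperazin-1-yl gives an 8.0-fold lower number from compound 3 to compound 4 (0.90 log units; beyond the scatter) at a place no earlier step touched. The (thiomorpholin-4-yl)carbonyl group also stands apart from 4-fluorophenyl with a 6.2-fold lower number from compound 2 to compound 4 (0.79 log units; beyond the scatter) and from 3-hydroxyphenyl with a 5.0-fold lower number from compound 1 to compound 4 (0.70 log units; beyond the scatter) while the earlier exchanges on that aromatic carbon all stayed within the scatter. Nothing measured here explains this ring's effect. A morpholin-4-yl or piperidin-1-yl ring on the same carbonyl carbon would show whether the sulfur atom itself counts.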